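Aryl swap at the hydrazone carbon: cytotoxicity expectation

The source may report more compounds than this note shows. Statements on the series, on what has been measured and on what is new or still open speak of the compounds shown alone.

Three compounds share a core and differ only in the aryl group on a carbon with a double bond to nitrogen. In an ADME assay on THP-1 cells (Homo sapiens) for cytotoxicity (on this read-out lower numbers stand for stronger inhibition and higher numbers for weaker inhibition), compound 1 `COc1ccccc1-c1nnc(-c2ccc(C(=O)N/N=C/c3ccc([N+](=O)[O-])cc3)cc2)o1` gives 203000 nM, compound 2 `COc1ccccc1-c1nnc(-c2ccc(C(=O)N/N=C/c3ccccc3O)cc2)o1` gives 207000 nM, and compound 3 `COc1ccccc1-c1nnc(-c2ccc(C(=O)N/N=C/c3cccnc3)cc2)o1` gives 167000 nM; all three numbers lie within the scatter of one another, as a 1.2-fold lower number from compound 1 to compound 3 (0.08 log units; within the scatter) and a 1.2-fold lower number from compound 2 to compound 3 (0.09 log units; within the scatter) show. Compound 4 `COc1ccccc1-c1nnc(-c2ccc(C(=O)N/N=C/c3cccc(O)c3O)cc2)o1` carries 2,3-dihydroxyphenyl in place of pyridin-3-yl on a carbon with a double bond to nitrogen. The steps bearing on this change are a 1.0-fold higher number from compound 1 to compound 2 (0.01 log units; within the scatter), a 1.2-fold lower number from compound 1 to compound 3 (0.08 log units; within the scatter) and a 1.2-fold lower number from compound 2 to compound 3 (0.09 log units; within the scatter), none beyond the scatter, so no step beyond the scatter is expected in this assay either, namely a 1.1-fold higher number from compound 3 to compound 4 (0.03 log units; within the scatter). Compound 4 is therefore estimated at 180000 nM, with a range from 90000 nM to 360000 nM.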

Compound 4, half-maximal inhibitory concentration: 102000 nM
For compound 4 the middle estimate is 1.8-fold (0.25 log units) above the measured one, and the stated range covers the measured number.
By their numbers in this assay, from the lowest: compounds 4, 3, 1 and 2 (each within the scatter of the next, the first and the last beyond it).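

In this assay, among these compounds, adding a hydroxy to the aryl group of compound 2 gives the first step at this position that is printed as beyond the scatter, though a modest one (a 2.0-fold lower number from compound 2 to compound 4 (0.31 log units; beyond the scatter)). The swaps from the other two aryl groups stay within the scatter (a 1.6-fold lower number from compound 3 to compound 4 (0.21 log units; within the scatter); a 2.0-fold lower number from compound 1 to compound 4 (0.30 log units; within the scatter)), so 2,3-dihydroxyphenyl stands apart only from 2-hydroxyphenyl. No measurement is available that accounts for this step. Still open, as far as these compounds go, is how an aryl group bearing an amine or a carboxylic acid in place of these hydroxy groups would read in this assay.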